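Methoxy added to a chalcone: expected cytotoxicity change

The source may hold more compounds than are shown below. What is called first, only, known or untested is meant among the compounds shown, and "the series" means these compounds.

Measured compounds:
Compound 1, `COc1ccc(CCC(=O)c2cccc(O)c2)cc1`: in an ADME assay on RAW264.7 cells (Mus musculus) for cytotoxicity, read by MTT assay, with a stated time of 24 h, tested at 10 ug/mL (a lower number here means a stronger effect, a higher number a weaker effect of the compound at the concentration tested), compound 1 gives 86.3%.
Compound 2, `COc1ccc(C(=O)/C=C/c2ccc(OC)c(OC)c2)c(O)c1`: in this assay compound 2 gives 70%.
Compound 3, `COc1ccc(CCC(=O)c2cccc(O)c2)c(OC)c1`: in this assay compound 3 gives 74.8%.

Compound 1 and compound 3 share a core and differ in one place: methoxy in place of hydrogen on an aromatic carbon. That change gives a number 11.5 percentage points lower from compound 1 to compound 3 (beyond the scatter), a modest move beyond the usual scatter. Compound 2 has the lowest of the three numbers; against compound 3 the gap is within the scatter, so no order between these two can be read, while against compound 1 its number is clearly lower. The difference between the core of compound 2 and the core of compound 1 is not broken down here.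

Compound 4, `COc1ccc(C(=O)/C=C/c2ccc(OC)c(OC)c2OC)c(O)c1`, has not yet been measured. It differs from compound 2 in one place: methoxy in place of hydrogen on an aromatic carbon. This is the same kind of change as that from compound 1 to compound 3, but not the same: in compound 4 the entering group is also ortho to a methoxy group, which is not so in compound 3. Within the data shown here, because of a number 11.5 percentage points lower from compound 1 to compound 3 (beyond the scatter), a downward step of similar size is expected, a number 9 percentage points lower from compound 2 to compound 4 (within the scatter), with only one prior example to rest on. For compound 4 the expected value is 61%, between 46% and 76%.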

Compound 4, a percentage reported as activity, at one concentration (the size of the read-out at that concentration, not a potency): 75.3%
Compound 4: the middle estimate sits 14.3 percentage points below what was measured, and the stated range covers the measured number.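

In this assay, the core of compound 2 takes up methoxy in place of hydrogen on an aromatic carbon with a number 5.3 percentage points higher from compound 2 to compound 4 (within the scatter), so on this core the change leaves no readable mark on the number. Set beside the earlier step, this shows that the change does not carry from one core to the other with the same size or direction, and that the downward step seen on the core of compound 1 cannot be assumed to hold for this series: the same change on two cores in this assay, a number 11.5 percentage points lower (beyond the scatter) from compound 1 to compound 3 and a number 5.3 percentage points higher (within the scatter) from compound 2 to compound 4, 16.8 percentage points apart, beyond the scatter of two such steps It does not show what sets the two steps apart, for in compound 4 the entering methoxy is ortho to a methoxy group and in compound 3 it is not, so the core and the place of the group vary together, and each core offers only a single example.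

The compounds shown leave open whether methoxy entering at the same place on both cores would give matching steps, which would separate the part played by the core from that of the place. They also leave open how a different entering group, such as an amine, a carboxylic acid or a chlorine atom, would behave on either core.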